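Adding a dimethylamino group to the phenyl ring of compound 2

The compounds below may be only part of what the source reports. "The series", "measured", "known", "first", "only" and "open" are said of these compounds alone.

Compound 1 `Cc1cccc(NC(=O)c2cc(-c3ccccc3)n(C)n2)n1` gives 95 nM in a functional assay on HEK293 cells for negative allosteric modulation of metabotropic glutamate receptor 5 (Homo sapiens), read by FLIPR and calcium flux; on this read-out lower numbers stand for stronger inhibition and higher numbers for weaker inhibition.
Compound 2 `Cc1cccc(NC(=O)c2nn(C)c(-c3ccccc3)c2C)n1` gives 4.4 nM.
Compound 3 `Cc1cccc(NC(=O)c2nn(C)c(-c3cc(F)cc(F)c3)c2C)n1` gives 5.3 nM.

Compound 2 and compound 3 sit within the scatter of each other, while compound 1 stands well above both, as the step of a 22-fold lower number from compound 1 to compound 2 (1.33 log units; beyond the scatter) shows. Compound 4 `Cc1cccc(NC(=O)c2nn(C)c(-c3ccc(N(C)C)cc3)c2C)n1` differs from compound 2 by dimethylamino in place of hydrogen on an aromatic carbon. Within the data shown here, only one measured step touches the same phenyl ring, a 1.2-fold higher number from compound 2 to compound 3 (0.08 log units; within the scatter), and it did not move the number beyond the scatter. Among the measured compounds shown here, no measured step places a group at this point of the ring. Compound 4 is therefore expected to remain close to compound 2 in this assay, with a 1.8-fold higher number from compound 2 to compound 4 (0.26 log units; within the scatter). Compound 4 is estimated at 8 nM, with a range from 2.5 nM to 30 nM.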

Compound 4, half-maximal inhibitory concentration: 645 nM
Beside the measured number, compound 4's estimate is 81-fold (1.91 log units) below it, outside the stated range (above it).
By their numbers in this assay, from the lowest: compounds 2 and 3 (each within the scatter of the next); then compound 1; then compound 4.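

In this assay, the step of a 150-fold higher number from compound 2 to compound 4 (2.17 log units; beyond the scatter) shows that the phenyl ring of compound 2 does not accept every change: dimethylamino in place of hydrogen, para to a large group, costs far more than the 3,5-difluorophenyl change did. The tolerance seen with compound 3 therefore does not extend to this position and this group. No measurement shown here accounts for the loss.

Going by these compounds, it remains open whether methoxy or chlorine at this same position would fare better, or whether a primary amine would match dimethylamino.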